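Compound 1 Gains an Aromatic Ring

The source may report more compounds than this note shows. Statements on the series, on what has been measured and on what is new or still open speak of the compounds shown alone.

Compound 1 (`COc1cc(NC(C)CCCNC(=O)NNC(=O)NCCO)c2ncccc2c1`) was tested in a functional assay on SW-620 cells (Homo sapiens) for inhibition, read by MTT assay, with a stated time of 4 days; on this read-out lower numbers stand for stronger inhibition and higher numbers for weaker inhibition. There, compound 1 gives only a limit, > 100000 nM, and not a number. Compound 2 (`COc1cc(NC(C)CCCNC(=O)NNC(=O)NCCCC(C)Nc2cc(OC)cc3cccnc23)c2ncccc2c1`) also gives only a limit, > 100000 nM. Among the compounds with values here, both measured compounds thus stand at the limit of > 100000 nM in this assay, at which 2 of the 2 values shown sit, and no step between measured compounds is available as a guide.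

Compound 3 (`COc1cc(NC(C)CCCNC(=O)Nc2ccc(Cl)c(C(F)(F)F)c2)c2ncccc2c1`) keeps the shared core of compound 1 but differs at one place: 4-chloro-3-(trifluoromethyl)phenyl in place of ((2-hydroxyethyl)carbamoyl)amino on an amide-type nitrogen. In words, 4-chloro-3-(trifluoromethyl)phenyl stands in place of ((2-hydroxyethyl)carbamoyl)amino on an amide-type nitrogen. The group that leaves has no ring, while the group that enters brings one six-membered aromatic ring of carbon only.

A swap of this size is expected to produce a real change beyond the scatter, towards stronger inhibition, although the measured compounds cannot fix its size. The estimated step in this assay is an at least 8.3-fold lower number from compound 1 to compound 3 (0.92 log units; beyond the scatter). The expected value for compound 3 is 12000 nM, with an estimated range from 3000 nM to 50000 nM.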

Compound 3, half-maximal inhibitory concentration: 23000 nM
Estimate against measurement, compound 3: 1.9-fold (0.28 log units) below; low and high end bracket the measured number.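

In this assay, putting 4-chloro-3-(trifluoromethyl)phenyl in place of ((2-hydroxyethyl)carbamoyl)amino on an amide-type nitrogen gives an at least 4.3-fold lower number from compound 1 to compound 3 (0.63 log units; beyond the scatter). This shows that a change at this one place can move the read-out beyond the scatter towards stronger inhibition, and the step is only a minimum, with its true size unknown, as the starting point is a limit and not a number. Only one of the three compounds shown can therefore be placed on the scale with an actual number: the limit of > 100000 nM in this assay, at which 2 of the 3 values shown sit.

The swap removes an open chain and brings in an aromatic ring, a chlorine and a trifluoromethyl group all at once, and the compounds shown do not separate the share of each part in the step. A plain phenyl ring, a phenyl ring carrying only the chlorine or only the trifluoromethyl group, or a simple butyl chain on the same amide-type nitrogen would be needed to tell whether the ring itself or the groups on it matter.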